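The compounds below may be only part of what the source reports. "The series", "measured", "known", "first", "only" and "open" are said of these compounds alone.

Three compounds have been measured in a functional assay on G-361 cells (Homo sapiens) for antiproliferative activity, with a stated time of 72 h; on this read-out lower numbers stand for stronger inhibition and higher numbers for weaker inhibition:

- Compound 1 `OC[C@H]1O[C@@H](n2cnc3c(NCc4cccc(F)c4)ncnc32)[C@H](O)[C@@H]1O`: > 166000 nM, a limit
- Compound 2 `OC[C@H]1O[C@@H](n2cnc3c(NCc4ccc(Br)cc4)ncnc32)[C@H](O)[C@@H]1O`: > 166000 nM, a limit
- Compound 3 `OC[C@H]1O[C@@H](n2cnc3c(NCc4ccc(Cl)cc4Cl)ncnc32)[C@H](O)[C@@H]1O`: 128000 nM

Of the three, only compound 3 has an actual number, 128000 nM. The other two values are limits. Compound 4 `OC[C@H]1O[C@@H](n2cnc3c(NCc4ccc(F)cc4Cl)ncnc32)[C@H](O)[C@@H]1O` differs from compound 3 by a single exchange, fluoro in place of chloro on an aromatic carbon, para to a large group and meta to a chloro group.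

Among the measured compounds shown here, no measured step makes this exact exchange. The nearest ones replace the whole halogenated phenyl group: an at least 1.2-fold lower number from compound 1 to compound 3 (0.11 log units; that floor lies within the scatter) and an at least 1.2-fold lower number from compound 2 to compound 3 (0.11 log units; that floor lies within the scatter). Neither shows a change beyond the scatter, so a single halogen exchange gives little reason to expect a large step in this assay. The reading for compound 4 must also be set against (the limit of > 166000 nM in this assay, at which 2 of the 3 values shown sit).

The expected change is a 1.2-fold higher number from compound 3 to compound 4 (0.07 log units; within the scatter), with nothing expected beyond the scatter in either direction. For compound 4 the estimated value is 150000 nM, with an expected range from 80000 nM to 280000 nM.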

Compound 4, half-maximal inhibitory concentration: > 166000 nM
Compound 4 ended at the assay's limit; the forecaster's own chance of this, stated with the estimate: 45%; middle value at least 1.1-fold (0.04 log units) away from the limit.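

In this assay, the exchange of chloro for fluoro on an aromatic carbon, para to a large group and meta to a chloro group, can now be read directly as a single change: an at least 1.2-fold higher number from compound 3 to compound 4 (0.11 log units; that floor lies within the scatter). This is only a floor on the size of the step, so it neither shows a real loss at this position nor rules out a larger one. The steps to compound 4 from compound 1 and from compound 2 cannot be read, since both ends of each are limits, and the series now sits mostly at one value: the limit of > 166000 nM in this assay, at which 3 of the 4 values shown sit.

Going by these compounds, how far compound 4 truly lies from compound 3 stays open, as compound 4 carries only a limit. Also open, on these data alone, is whether a methoxy or trifluoromethyl group on this same aromatic carbon would give a measurable number in this assay.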